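Swapping an ortho substituent on the benzamide ring

A few compounds are considered here, and "the series" means these few. Any claim that something is new, unique, unknown or untested is made for them only; others in the source may bear on it.

Measured so far:
Compound 1 `Nc1ccc(C(=O)Nc2nc(-c3ccccc3)nc3c2nnn3Cc2ccccc2)cc1`: 7.1 nM
Compound 2 `O=C(Nc1nc(-c2ccccc2)nc2c1nnn2Cc1ccccc1)c1ccccc1C(F)(F)F`: 550 nM

Both compounds share the same core and differ only in the group carried on the carbonyl carbon. Among the measured compounds shown here, in an assay (strain Wistar) for displacement of a labelled ligand from adenosine receptor A1 (Rattus norvegicus), read by scintillation counting (a higher number here means a weaker inhibitor, a lower number a stronger inhibitor), compound 1 gives 7.1 nM, while compound 2 gives 550 nM, and the single step between them, a 77-fold higher number from compound 1 to compound 2 (1.89 log units; beyond the scatter), shows how strongly this ring can shape the result. Compound 2 thus stands at the highest of the two numbers, the weaker of the two.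

Compound 3 `COc1ccccc1C(=O)Nc1nc(-c2ccccc2)nc2c1nnn2Cc1ccccc1` has not been measured yet. Its change from compound 2 is methoxy in place of trifluoromethyl on an aromatic carbon, sitting on an aromatic carbon of a six-membered ring of carbon only, ortho to a large group. For the measured compounds named here, no measured step matches this change: the one step available swaps the whole ring pattern, not a single ortho group, so it only sets the scale of what is possible here. The expected step is therefore modest and uncertain, with direction guessed towards a lower number, a 2.8-fold lower number from compound 2 to compound 3 (0.44 log units; beyond the scatter). Compound 3 is estimated at 200 nM, with a range from 40 nM to 1500 nM.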

Compound 3, inhibition constant: 1520 nM
For compound 3 the middle estimate is 7.6-fold (0.88 log units) below the measured one; the measured number lies above the stated range.
By their numbers in this assay, from the lowest: compound 1; then compound 2; then compound 3.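

In this assay, among the compounds shown here, replacing trifluoromethyl with methoxy, ortho to a large group, gives a 2.8-fold higher number from compound 2 to compound 3 (0.44 log units; beyond the scatter) and is the first change made at this position with the rest of the ring left alone. It shows that the number responds to the choice of group here, though far less than it did to the whole change of ring pattern. The wider gap, a 210-fold higher number from compound 1 to compound 3 (2.33 log units; beyond the scatter) in this assay, shows that 2-methoxyphenyl is a poorer replacement for 4-aminophenyl than 2-(trifluoromethyl)phenyl was, and no available evidence explains why either group gives the number it does.

Compound 1 differs from the other two in both the group it carries and where that group sits on the ring, so these two effects cannot be separated from the compounds shown. As far as these compounds go, it also remains open whether a different group at this ortho position, such as a chlorine atom or a hydroxyl, would bring the number closer to that of compound 1 or push it higher still.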